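Fluoro Substitution on the Fused Ring of Three Acrylamides

A few compounds are considered here, and "the series" means these few. Any claim that something is new, unique, unknown or untested is made for them only; others in the source may bear on it.

Compound 3 `NC(=O)/C=C1\CCc2cc(F)ccc21` gives 54% in a functional assay on the whole organism with Rattus norvegicus as the target, at a dose of 20 mg/kg by the oral route; a higher number here means more inhibition at the dose given (going by the name of the read-out), a lower number less inhibition. Compound 2 `NC(=O)/C=C1\CCc2cc(F)cc(F)c21` carries one further fluoro group, (fluoro in place of hydrogen on an aromatic carbon); in this assay compound 2 gives 54%, and the step of no change at the digits printed from compound 3 to compound 2 (within the scatter). Compound 1 `NC(=O)/C=C1\CCc2c(F)cccc21` has the same atoms as compound 3 joined differently; the difference between the two cores is not broken down here. In this assay compound 1 gives 40%, the lowest of the three numbers, lying beyond the scatter below both compound 2 and compound 3. Compound 4 `NC(=O)/C=C1\CCc2c(F)ccc(F)c21` is not yet measured. Among the measured compounds shown here, it arises from compound 1 by fluoro in place of hydrogen on an aromatic carbon, the same kind of change as the one between compound 3 and compound 2, although the entering fluoro group here sits para to a fluoro group, whereas in compound 2 it sits meta to a fluoro group. Because the earlier step of no change at the digits printed from compound 3 to compound 2 (within the scatter), the change is expected to leave compound 4 near its parent, an estimated step of a number 4 percentage points higher from compound 1 to compound 4 (within the scatter). Compound 4 is therefore estimated at 44%, with a likely range from 30% to 58%.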

Compound 4, a percentage reported as inhibition, in the whole organism at one dose (the size of the read-out at that dose, not a potency): 67%
The estimate for compound 4 lay 23 percentage points below the measured number; measured number outside the range, above it.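

In this assay, placing the fluoro group on the core of compound 1 gives a number 27 percentage points higher from compound 1 to compound 4 (beyond the scatter). The same replacement thus does not carry over unchanged from one core to the other in this series: the same change on two cores in this assay, no change at the digits printed (within the scatter) from compound 3 to compound 2 and a number 27 percentage points higher (beyond the scatter) from compound 1 to compound 4, 27 percentage points apart, beyond the scatter of two such steps. This shows that, across these two pairs, the result of adding a fluoro group differs with the compound that receives it; it does not show why, nor does it separate the core from the place of the entering group, which in compound 4 is para to a fluoro group, and two pairs set no rule for any further core.

The compounds shown carry only hydrogen or fluoro on the aromatic ring, which leaves open whether a chloro group or a methoxy group there would follow the step to compound 2 or the step to compound 4. On these data alone, it also remains open how these steps would look with a carboxylic acid in place of the amide.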